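This account rests on a few compounds, and the source may have more. Where it says the series, first, only, none or still open, it means among the compounds named here.

Measured so far in a functional assay on HepG2 cells (Homo sapiens) for antiproliferative activity, read by MTT assay; a lower number here means a stronger inhibitor, a higher number a weaker inhibitor:

Compound 1 `CNC(=O)c1oc2nc(-c3ccccc3)cc(C(F)(F)F)c2c1N`: 41200 nM
Compound 2 `Nc1c(C(=O)N/N=C/c2ccc(Cl)cc2)oc2nc(-c3ccccc3)cc(C(F)(F)F)c12`: 12100 nM
Compound 3 `CCCNC(=O)c1oc2nc(-c3ccccc3)cc(C(F)(F)F)c2c1N`: 37400 nM

All three compounds share one core and differ only in the group carried on the amide-type nitrogen. Compound 3 gives 37400 nM in this assay, the second highest of the three numbers; it sits close to compound 1, the two differing by a 1.1-fold lower number from compound 1 to compound 3 (0.04 log units; within the scatter), and farthest from compound 2, separated by a 3.1-fold higher number from compound 2 to compound 3 (0.49 log units; beyond the scatter).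

Compound 4 `Nc1c(C(=O)N/N=C/c2ccc(Br)cc2)oc2nc(-c3ccccc3)cc(C(F)(F)F)c12` has not yet been measured. Relative to compound 3 the change is a group of 9 heavy atoms (7 carbon, 1 nitrogen, 1 bromine; one six-membered aromatic ring of carbon only) in place of a group of 3 heavy atoms (3 carbon; no ring), on an amide-type nitrogen. Within the data shown here, the group entering differs from the one in compound 2 only in carrying a bromine atom where compound 2 carries a chlorine atom.

Among the measured compounds shown here, two measured steps bear on this change. Going from the small methyl group to the chlorine-bearing hydrazone gave a 3.4-fold lower number from compound 1 to compound 2 (0.53 log units; beyond the scatter), and the reverse exchange, from that hydrazone to propyl, gave a 3.1-fold higher number from compound 2 to compound 3 (0.49 log units; beyond the scatter). The new step repeats the first of these with bromine instead of chlorine, so a drop of about the same size is expected: a 3.4-fold lower number from compound 3 to compound 4 (0.53 log units; beyond the scatter). Compound 4 is therefore estimated to give 11000 nM in this assay, with a range from 4500 nM to 27000 nM.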

Compound 4, half-maximal inhibitory concentration: 19900 nM
Estimate against measurement, compound 4: 1.8-fold (0.26 log units) below; low and high end bracket the measured number.
By their numbers in this assay, from the lowest: compounds 2, 4, 3 and 1 (each within the scatter of the next, the first and the last beyond it).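

In this assay bromo in place of chloro on an aromatic carbon gives a 1.6-fold higher number from compound 2 to compound 4 (0.22 log units; within the scatter), so the two halogen-bearing hydrazones cannot be told apart at this position. Against the small chains the picture is less clear than compound 2 alone suggested: the bromine-bearing group gives a 2.1-fold lower number from compound 1 to compound 4 (0.32 log units; beyond the scatter), a modest step, when it replaces methyl, but a 1.9-fold lower number from compound 3 to compound 4 (0.27 log units; within the scatter) when it replaces propyl. The advantage over both chains that compound 2 showed beyond the scatter therefore holds for compound 4 only against methyl, and no measurement shown here accounts for these numbers.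

The compounds shown leave open how the hydrazone would read with hydrogen, fluoro or methoxy on the aromatic ring in place of the halogens, which would show whether the halogen matters at all. A chain longer than propyl, such as hexyl, or an amide nitrogen bearing a plain phenyl ring, would also help to show whether the size of the group or the hydrazone itself goes with the lower numbers.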